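Fluoro to trifluoromethyl in an arylpiperazine succinimide series

The compounds below may be only part of what the source reports. "The series", "measured", "known", "first", "only" and "open" are said of these compounds alone.

Compound 1 `CC(C(=O)N1CCN(c2ccccc2F)CC1)N1C(=O)CCC1=O` gives 50% in a functional assay on the whole organism (strain Swiss) with Mus musculus as the target, in the maximal electroshock model, with a stated time of 0.5 h, at a dose of 300 mg/kg by the intraperitoneal route (on this read-out higher numbers stand for a stronger effect at the one dose given and lower numbers for a weaker effect), and stands highest of the three measured compounds. Compound 3 `CCC(C(=O)N1CCN(c2ccc(F)cc2)CC1)N1C(=O)CCC1=O` gives 25% in this assay, and compound 2 `CCC(C(=O)N1CCN(c2ccc(C(F)(F)F)cc2)CC1)N1C(=O)CCC1=O` gives 0%. The change trifluoromethyl in place of fluoro on an aromatic carbon made the step of a number 25 percentage points lower from compound 3 to compound 2 (beyond the scatter). How the core of compound 1 differs from that of compound 3 is not broken down here.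

Compound 4 `CC(C(=O)N1CCN(c2ccccc2C(F)(F)F)CC1)N1C(=O)CCC1=O` is not yet measured. It differs from compound 1 by trifluoromethyl in place of fluoro on an aromatic carbon. This is the same kind of change as that from compound 3 to compound 2, but not the same: there the trifluoromethyl sits para to a large group, here ortho to a large group. Among the compounds with values here, only one earlier instance of the change exists, so the expectation rests on a single step. Because the same kind of change gave a number 25 percentage points lower from compound 3 to compound 2 (beyond the scatter), a step of similar size is expected, namely a number 25 percentage points lower from compound 1 to compound 4 (beyond the scatter). Compound 4 is therefore estimated at 25% in this assay, with a range from 0% to 50%.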

Compound 4, a percentage reported as activity, at one dose (the size of the read-out at that dose, not a potency): 100%
Compound 4: middle estimate off by 75 percentage points, on the low side; measured number above the stated range.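

In this assay, trifluoromethyl in place of fluoro on an aromatic carbon, ortho to a large group, gave a number 50 percentage points higher from compound 1 to compound 4 (beyond the scatter). The change therefore does not carry a fixed step from one core to another in this series, and even the direction of the earlier step fails to hold: the same change on two cores in this assay, a number 25 percentage points lower (beyond the scatter) from compound 3 to compound 2 and a number 50 percentage points higher (beyond the scatter) from compound 1 to compound 4, 75 percentage points apart, beyond the scatter of two such steps The two pairs differ both in where the group sits on the aromatic ring and in the rest of the core, so these two steps cannot show which of those differences goes with the reversal, nor do they give a rule for any further core.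

The compounds shown leave open whether trifluoromethyl ortho to a large group gives a similar step on the core of compound 3. They also leave open how a chloro, a methoxy or a nitrile on that aromatic carbon would compare with fluoro and trifluoromethyl on the core of compound 1.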